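The source may report more compounds than this note shows. Statements on the series, on what has been measured and on what is new or still open speak of the compounds shown alone.

Measured compounds:
compound 1, `N#CCC1=C(C#N)CC(c2ccc([N+](=O)[O-])cc2)=C(CC(=O)c2ccc([N+](=O)[O-])cc2)O1`: 80 nM
compound 2, `N#CCC1=NN=C(c2ccc(Br)cc2)C(CC(=O)c2ccc([N+](=O)[O-])cc2)O1`: 23000 nM
compound 3, `N#CCC(=O)N/N=C(/CBr)c1ccc(Br)cc1`: 10000 nM

In a functional assay on NCI-H460 cells (Homo sapiens) for inhibition, read by sulforhodamine B assay, with a stated time of 48 h (on this read-out lower numbers stand for stronger inhibition of growth and higher numbers for weaker inhibition of growth), compound 1 stands lowest of the three, the others lying far beyond the scatter above it. Compound 4, `N#CCC1=C(C#N)CC(c2ccc(Br)cc2)=C(CC(=O)c2ccc([N+](=O)[O-])cc2)O1`, keeps the core of compound 1 and differs from it only by bromo in place of nitro on an aromatic carbon. Among the measured compounds shown here, no measured pair shows this change on the shared core; compound 2 carries a bromophenyl group but sits on a different core, so its number cannot be read as the effect of the exchange. The step from compound 1 to compound 4 is expected to be a modest weakening, likely only somewhat beyond the scatter, a 3.8-fold higher number from compound 1 to compound 4 (0.57 log units; beyond the scatter). Compound 4 is therefore estimated at 300 nM, within a range of 60 nM to 2000 nM.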

Compound 4, concentration for 50% growth inhibition: 10 nM
For compound 4 the middle estimate is 30-fold (1.48 log units) above the measured one; measured number outside the range, below it.
By their numbers in this assay, from the lowest: compound 4; then compound 1; then compound 3; then compound 2.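

In this assay, bromo in place of nitro on the aromatic carbon para to a large group gives an 8.0-fold lower number from compound 1 to compound 4 (0.90 log units; beyond the scatter) on the shared core. Among the compounds shown here, no earlier pair held this change, so this is the first reading of this position: the nitro group on this ring is not needed for a low number here, and the 4-bromophenyl compound stands lower. Nothing measured here explains the step. Going by these compounds, whether chloro, methoxy or an amine at this carbon would keep the number remains open. So does the part played by the nitro group on the other aromatic ring.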